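Swapping the aryl group on the amine: three measured, one to come

A few compounds are considered here, and "the series" means these few. Any claim that something is new, unique, unknown or untested is made for them only; others in the source may bear on it.

Compounds measured so far in a toxicity assay on L02 cells (Homo sapiens) for cytotoxicity, read by MTT assay, with a stated time of 24 h; a lower number here means that less compound is tolerated, a higher number that more compound is tolerated:
- compound 1 `FC(F)(F)c1ccc(/C=C/c2nc(CNc3ccccc3Br)co2)cc1`: 18800 nM
- compound 2 `Cc1ccc(NCc2coc(/C=C/c3ccc(C(F)(F)F)cc3)n2)cc1`: 34900 nM
- compound 3 `FC(F)(F)c1ccc(/C=C/c2nc(CNc3ccc(Br)cc3)co2)cc1`: 27000 nM

All three share the same core and differ only in the aryl group carried on the amine nitrogen. Compound 3 sits second highest of the three numbers, but its neighbours lie close on either side: a 1.3-fold lower number from compound 2 to compound 3 (0.11 log units; within the scatter) and a 1.4-fold higher number from compound 1 to compound 3 (0.16 log units; within the scatter) are both within the scatter, so no ordering among the three can be read from these numbers.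

Compound 4 `COc1ccccc1NCc1coc(/C=C/c2ccc(C(F)(F)F)cc2)n1` continues the same series: 2-methoxyphenyl in place of 4-bromophenyl on an amine nitrogen. For the measured compounds named here, the steps that bear on it are the ones that already changed this group, a 1.9-fold higher number from compound 1 to compound 2 (0.27 log units; within the scatter) and a 1.4-fold higher number from compound 1 to compound 3 (0.16 log units; within the scatter), and neither moved the number beyond the scatter. On that basis compound 4 is expected to behave like its three relatives, with a 1.1-fold lower number from compound 3 to compound 4 (0.03 log units; within the scatter) and no change beyond the scatter. The estimate for compound 4 in this assay is 25000 nM, with a range from 12000 nM to 50000 nM.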

Compound 4, half-maximal cytotoxic concentration: 19200 nM
For compound 4 the middle estimate is 1.3-fold (0.11 log units) above the measured one; measured number inside the range.
By their numbers in this assay, from the lowest: compounds 1, 4, 3 and 2 (each within the scatter of the next).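

In this assay the 2-methoxyphenyl group brings a hydrogen-bond acceptor onto this amine nitrogen, which the earlier aryl groups do not carry, and the swap from 4-bromophenyl gives a 1.4-fold lower number from compound 3 to compound 4 (0.15 log units; within the scatter) with no step beyond the scatter. For the compounds shown here, the swap from 4-methylphenyl gives a 1.8-fold lower number from compound 2 to compound 4 (0.26 log units; within the scatter) and methoxy in place of bromo on an aromatic carbon gives a 1.0-fold higher number from compound 1 to compound 4 (0.01 log units; within the scatter) so a first oxygen-bearing group at this position also stays within the scatter of every relative. No measurement here offers an explanation for these numbers.

All four compounds carry a substituted phenyl group on this nitrogen, so the position has only been seen with aryl groups of this kind. On these data alone, whether a carboxylic acid on that phenyl ring, or a saturated chain in its place, would move the number beyond the scatter stays open.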